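A Pyrrolidine for Dimethylamino at the Cytotoxicity Limit

The source may report more compounds than this note shows. Statements on the series, on what has been measured and on what is new or still open speak of the compounds shown alone.

compound 1 `Nc1nc(OCC(F)(F)F)c2ncn(/C=C3/CC3(CO)CO)c2n1` gives > 20000 nM
compound 2 `CN(C)c1nc(N)nc2c1ncn2/C=C1/CC1(CO)CO` gives > 20000 nM
compound 3 `Nc1nc2c(ncn2/C=C2/CC2(CO)CO)c(=O)[nH]1` gives > 20000 nM

All three readings come from an ADME assay on BCBL1 cells (Homo sapiens) for cytotoxicity, with a stated time of 7 days (on this read-out lower numbers stand for higher toxicity in this test and higher numbers for lower toxicity in this test), and none of them is a number. Compound 2 stands at > 20000 nM and this is a limit of the assay. Among the compounds with values here, the series so far offers only the limit of > 20000 nM in this assay, at which 3 of the 3 values shown sit, and so gives compound 2 no rank among the others.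

The next change replaces the dimethylamino of compound 2 with pyrrolidin-1-yl on an aromatic carbon, next to the ring nitrogen, and leads to compound 4 `Nc1nc(N2CCCC2)c2ncn(/C=C3/CC3(CO)CO)c2n1` in this way pyrrolidin-1-yl in place of dimethylamino on an aromatic carbon and no other part of the structure differs.

The nearest measured change at this carbon is a step that the two limits leave unreadable from compound 1 to compound 2 and it offers no size to carry over. No step beyond the usual scatter is therefore expected in this assay, and no direction can be given. The expected change is a step that the limit leaves unreadable from compound 2 to compound 4 and it rests on the limit of compound 2. Compound 4 is estimated at 25000 nM with an expected range from 10000 nM to 50000 nM and will most likely again be reported only as a limit.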

Compound 4, half-maximal cytotoxic concentration: > 20000 nM
Compound 4: a limit, no number; the forecaster's own chance of this, stated with the estimate: 80%; the middle value is on the limit's open side.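

No step between compound 1, compound 2 and compound 4 can be read in this assay, because each of the three stands at a limit and not at a number: the limit of > 20000 nM in this assay, at which 4 of the 4 values shown sit.

The compounds shown leave open whether any group on this aromatic carbon would give a reading that is a number rather than a limit.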